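The compounds below may be only part of what the source reports. "The series", "measured", "known", "first", "only" and "open" are said of these compounds alone.

Measured compounds:
- compound 1, `CC(C(=O)N1CCN(c2ccc(F)cc2)CC1)N1C(=O)CCC1=O`: 100%
- compound 2, `CC(C(=O)N1CCN(c2cccc(C(F)(F)F)c2)CC1)N1C(=O)CCC1=O`: 75%
- compound 3, `CCC(C(=O)N1CCN(c2cccc(Cl)c2)CC1)N1C(=O)CCC1=O`: 75%

All three were tested in a functional assay on the whole organism (strain Swiss) with Mus musculus as the target, in the maximal electroshock model, with a stated time of 0.25 h, at a dose of 300 mg/kg by the intraperitoneal route; on this read-out higher numbers stand for a stronger effect at the one dose given and lower numbers for a weaker effect. On these numbers compound 3 stands level with compound 2, and the two of them together give the lowest of the three readings. Compound 1 lies higher than compound 3 by a gap that goes beyond the usual scatter, whereas the gap between compound 3 and compound 2 stays within it.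

Compound 4, `CC(C(=O)N1CCN(c2cccc(Cl)c2)CC1)N1C(=O)CCC1=O`, has not yet been measured. It differs from compound 3 in one place: hydrogen in place of methyl on a saturated chain carbon, two bonds along the chain from an amide-type nitrogen in a ring and a carbonyl carbon. For the measured compounds named here, no pair of measured compounds shows this change on its own, so there is no measured step to lean on. The three readings all sit in the upper part of the scale, and none of them points to a large effect of a change of this size. The step of no change at the digits printed from compound 3 to compound 4 (within the scatter) is expected to be small, or none beyond the scatter. Compound 4 is therefore expected to give about 75%, somewhere between 50% and 100%.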

Compound 4, a percentage reported as activity, at one dose (the size of the read-out at that dose, not a potency): 75%
Estimate against measurement, compound 4: no gap at the digits printed; measured number inside the range.
By their numbers in this assay, from the lowest: compounds 2, 3 and 4 (each within the scatter of the next); then compound 1.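

In this assay, for the compounds shown here, no change at the digits printed from compound 3 to compound 4 (within the scatter) gives the first direct reading of a change at this saturated chain carbon: going from ethyl to methyl leaves the number where it was at this single dose. Going by these compounds alone, with methyl held constant at that carbon, no change at the digits printed from compound 2 to compound 4 (within the scatter) shows chloro in place of trifluoromethyl on an aromatic carbon also stays within the scatter, whereas a number 25 percentage points lower from compound 1 to compound 4 (beyond the scatter) isolates 3-chlorophenyl in place of 4-fluorophenyl on an amine nitrogen in a ring as the one change here that goes beyond it. No measured evidence is available to explain any of these steps.

Going by these compounds, it remains open whether a longer chain such as propyl, or an amine, at this carbon would change the reading, and whether ethyl would also leave compound 1 unchanged. A reading at one dose is not a potency, so equal numbers may still conceal differences at lower doses.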